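Replacing trifluoromethyl with hydroxy on the shared core

A few compounds are considered here, and "the series" means these few. Any claim that something is new, unique, unknown or untested is made for them only; others in the source may bear on it.

Measured in an ADME assay for permeability, using PAMPA, with a stated time of 3 h; on this read-out higher numbers stand for higher permeability and lower numbers for lower permeability:
Compound 1 `O=C(Nc1ccc([N+](=O)[O-])cc1)c1cc(Cl)ccc1O`: 12.4 10^-6 cm/s
Compound 2 `O=C(Nc1ccc(C(F)(F)F)cc1)c1cc(Cl)ccc1O`: 6.9 10^-6 cm/s

Compound 2 lies within the usual scatter of compound 1, so the two values cannot be told apart. Compound 3 `O=C(Nc1ccc(O)cc1)c1cc(Cl)ccc1O` carries hydroxy in place of trifluoromethyl on an aromatic carbon. Going by the values given here, the only measured step, a 1.8-fold lower number from compound 1 to compound 2 (0.25 log units; within the scatter), exchanged nitro for trifluoromethyl and stayed within the scatter. Neither of its compounds carries hydroxy, so it is a loose guide. With that single step to go on, no change beyond the scatter is expected in this assay, and the expected step is a 1.5-fold lower number from compound 2 to compound 3 (0.19 log units; within the scatter). For compound 3 the estimate is 4.5 10^-6 cm/s, with an expected range from 1.5 10^-6 cm/s to 13 10^-6 cm/s.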

Compound 3, apparent permeability: 33.1 10^-6 cm/s
Beside the measured number, compound 3's estimate is 7.4-fold (0.87 log units) below it; measured number above the stated range.
By their numbers in this assay, from the lowest: compounds 2 and 1 (each within the scatter of the next); then compound 3.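

In this assay hydroxy on this aromatic carbon gives a clear change against both earlier groups: against trifluoromethyl (a 4.8-fold higher number from compound 2 to compound 3 (0.68 log units; beyond the scatter)) and against nitro (a 2.7-fold higher number from compound 1 to compound 3 (0.43 log units; beyond the scatter)). The group at this position can therefore move the read-out beyond the scatter, which the exchange of nitro for trifluoromethyl did not show. Nothing measured here offers a reason for the higher number. The compounds shown leave open whether an amine or a carboxylic acid on the same carbon would read like hydroxy, or like nitro and trifluoromethyl.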